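The source may report more compounds than this note shows. Statements on the series, on what has been measured and on what is new or still open speak of the compounds shown alone.

Compound 1 `O=C(CCN1CCN(c2ccc(Cl)cc2)CC1)c1ccc(Br)cc1`: 52100 nM. Compound 2 `O=C(CCN1CCN(c2ccc([N+](=O)[O-])cc2)CC1)c1ccc(Br)cc1`: 79800 nM. Compound 3 `O=C(CCN1CCN(c2ccc(Cl)cc2)CC1)c1ccc(OC(F)(F)F)cc1`: 95600 nM.

All three were tested in an ADME assay on Vero cells (Chlorocebus sabaeus) for cytotoxicity, read by resazurin assay, with a stated time of 72 h; on this read-out higher numbers stand for weaker inhibition and lower numbers for stronger inhibition. Compound 1 and compound 2 differ by nitro in place of chloro on an aromatic carbon, and the step between them is a 1.5-fold higher number from compound 1 to compound 2 (0.19 log units; within the scatter). The cores of compound 1 and compound 3 differ by trifluoromethoxy in place of bromo on an aromatic carbon, and that step is a 1.8-fold higher number from compound 1 to compound 3 (0.26 log units; within the scatter). The numbers for compound 3, compound 2 and compound 1 all lie within the scatter of one another, so the three compounds are not separated by this assay.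

Compound 4 `O=C(CCN1CCN(c2ccc([N+](=O)[O-])cc2)CC1)c1ccc(OC(F)(F)F)cc1` has not yet been measured. It differs from compound 3 by nitro in place of chloro on an aromatic carbon, which is the same change as that from compound 1 to compound 2; it occurs twice among these compounds, and in both cases the surroundings of the place are the same. Because the earlier step was a 1.5-fold higher number from compound 1 to compound 2 (0.19 log units; within the scatter), the step from compound 3 to compound 4 in this assay is expected to be of similar size, a 1.4-fold higher number from compound 3 to compound 4 (0.13 log units; within the scatter), and this expectation rests on that single earlier pair. Compound 4 is accordingly estimated at 130000 nM, with a likely range from 70000 nM to 250000 nM.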

Compound 4, half-maximal inhibitory concentration: 93200 nM
The estimate for compound 4 lay 1.4-fold (0.14 log units) above the measured number, and the stated range covers the measured number.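

Nitro in place of chloro gives a 1.0-fold lower number from compound 3 to compound 4 (0.01 log units; within the scatter) in this assay, and the change reads the same on both cores: the same change on two cores in this assay, a 1.5-fold higher number (0.19 log units; within the scatter) from compound 1 to compound 2 and a 1.0-fold lower number (0.01 log units; within the scatter) from compound 3 to compound 4, 1.6-fold (0.20 log units) apart, within the scatter of two such steps. Trifluoromethoxy in place of bromo gives a 1.2-fold higher number from compound 2 to compound 4 (0.07 log units; within the scatter), and this change also reads the same on both cores: the same change on two cores in this assay, a 1.8-fold higher number (0.26 log units; within the scatter) from compound 1 to compound 3 and a 1.2-fold higher number (0.07 log units; within the scatter) from compound 2 to compound 4, 1.6-fold (0.20 log units) apart, within the scatter of two such steps. For the compounds shown here, this shows that neither change gave a different result when carried to a second core, but every step lies within the scatter, so it does not show that either change has a real effect that carries over, and each comparison rests on only two pairs.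

The compounds shown leave open whether an amine or a carboxylic acid in place of the nitro group, or a longer chain joining the carbonyl to the rest of the molecule, would give a step beyond the scatter in this assay. They also leave open how these two changes would read on other cores.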